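Methyl to isopropyl on the ester oxygen: compound 3

The compounds below may be only part of what the source reports. "The series", "measured", "known", "first", "only" and "open" are said of these compounds alone.

Measured so far:
compound 1 `COc1ccc(Cl)cc1CSc1nc2ccccc2n1CC(=O)O` — 740 nM
compound 2 `COC(=O)c1ccc(OC)c(CSc2nc3ccccc3n2CC(=O)O)c1` — 29 nM

Both compounds were tested in an assay on HEK293 cells for displacement of a labelled ligand from prostaglandin D2 receptor 2 (Homo sapiens); a lower number here means a stronger inhibitor, a higher number a weaker inhibitor. Compound 1 gives 740 nM, and compound 2 gives 29 nM. Within the data shown here, the single measured step, a 26-fold lower number from compound 1 to compound 2 (1.41 log units; beyond the scatter), is the only one available and puts compound 2 at the lowest number of the two, with compound 1 the nearest at a much higher number. Compound 3 `COc1ccc(C(=O)OC(C)C)cc1CSc1nc2ccccc2n1CC(=O)O` differs from compound 2 by isopropyl in place of methyl on an oxygen next to a carbonyl group, on an oxygen next to a carbonyl group; read one bond further out, methoxycarbonyl becomes isopropoxycarbonyl. Among the measured compounds shown here, no measured step touches this oxygen: the one known step concerns a change on an aromatic carbon, so it gives no guidance for the size or direction here. For compound 3 the working expectation is therefore a step of a 1.4-fold higher number from compound 2 to compound 3 (0.14 log units; within the scatter) in this assay, i.e. nothing clearly beyond the scatter, with a wide range to allow for either direction. Compound 3 is thus estimated at 40 nM, between 10 nM and 160 nM.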

Compound 3, half-maximal inhibitory concentration: 150 nM
Beside the measured number, compound 3's estimate is 3.8-fold (0.57 log units) below it, and the stated range covers the measured number.
By their numbers in this assay, from the lowest: compound 2; then compound 3; then compound 1.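

In this assay, the oxygen next to the carbonyl group is sensitive to what it carries: isopropyl in place of methyl gives a 5.2-fold higher number from compound 2 to compound 3 (0.71 log units; beyond the scatter), so this change makes for a weaker inhibitor by a step beyond the scatter. Isopropoxycarbonyl still keeps a clear advantage over chloro on the aromatic carbon, with a 4.9-fold lower number from compound 1 to compound 3 (0.69 log units; beyond the scatter), although this is a smaller gain than methoxycarbonyl gives with a 26-fold lower number from compound 1 to compound 2 (1.41 log units; beyond the scatter); the benefit of replacing chloro therefore depends on the group on the ester oxygen, not only on the presence of the ester. No evidence is available on the cause of the step from methyl to isopropyl.

From the compounds shown here alone, with only methyl and isopropyl on this oxygen, it remains open whether an ethyl group would fall nearer compound 2 or compound 3, and whether a tert-butyl group or a longer chain would continue the direction of the step. Going by these compounds, it is also open whether a carboxylic acid or an amide in place of the ester would retain the standing of compound 2.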